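This account rests on a few compounds, and the source may have more. Where it says the series, first, only, none or still open, it means among the compounds named here.

Compound 1 `CC(=O)OC/C1=C/C[C@](C)(CCC=C(C)C)/C=C/[C@@H](OC(=O)C=C(C)C)[C@](C)(O)/C=C/C1=O` was tested in a functional assay on SW480 cells (Homo sapiens) for antiproliferative activity, read by MTT assay, with a stated time of 48 h (on this read-out higher numbers stand for weaker inhibition and lower numbers for stronger inhibition), and gave 2950 nM. Its companion compound 2 `CC(=O)O[C@]1(C)/C=C/C(=O)/C(CO)=C\C[C@](C)(CCC=C(C)C)/C=C/[C@H]1OC(=O)C=C(C)C` gave 2010 nM in this assay; the two numbers lie within the usual scatter of one another, so neither compound can be set apart from the other on these data. Compound 3 `CC(C)=CCC[C@]1(C)/C=C/[C@@H](OC(=O)C=C(C)C)[C@](C)(O)/C=C/C(=O)/C(C(=O)N2CCCC2)=C\C1` has not yet been measured; it differs from compound 1 by (pyrrolidin-1-yl)carbonyl in place of acetoxymethyl on a double-bonded ring carbon. Among the measured compounds shown here, no measured pair shows the effect of such a change, so compound 3 is expected to stay close to compound 1 in this assay, with a step of a 1.0-fold higher number from compound 1 to compound 3 (0.01 log units; within the scatter) that may not exceed the scatter. Compound 3 is therefore estimated at 3000 nM, within a range from 800 nM to 12000 nM.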

Compound 3, half-maximal inhibitory concentration: 15100 nM
Compound 3: the middle estimate sits 5.0-fold (0.70 log units) below what was measured; the measured number lies above the stated range.
By their numbers in this assay, from the lowest: compounds 2 and 1 (each within the scatter of the next); then compound 3.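

In this assay, (pyrrolidin-1-yl)carbonyl in place of acetoxymethyl on this double-bonded ring carbon gives a 5.1-fold higher number from compound 1 to compound 3 (0.71 log units; beyond the scatter), so the number at this position responds to the group placed there. The earlier compounds shown here gave no such step, as their two numbers lay within the scatter of each other. Nothing measured here accounts for this step.

The compounds shown leave open whether a dimethylaminocarbonyl group, a (piperidin-1-yl)carbonyl group or a carboxylic acid on this carbon would give a number like that of compound 1 or that of compound 3.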